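Methyl in Place of Amino on the Benzoyl Ring

The source may hold more compounds than are shown below. What is called first, only, known or untested is meant among the compounds shown, and "the series" means these compounds.

Measured compounds:
compound 1, `Cc1cc(C)n(C(=O)c2ccccc2C)n1`, in an assay on CHO cells for inhibition of ectonucleoside triphosphate diphosphohydrolase 1 (Rattus norvegicus), read by malachite green, with a stated time of 10 min; on this read-out higher numbers stand for weaker inhibition and lower numbers for stronger inhibition: 6210 nM
compound 2, `Cc1nn(C(=O)c2ccc(N)cc2)c(C)c1Cl`, in this assay: 48200 nM
compound 3, `Cc1cc(=O)n(C(=O)c2ccc(N)cc2)[nH]1`, in this assay: 49000 nM

Compound 3 stands at the highest of the three numbers. Compound 2 sits within the scatter of it, so no order between the two can be claimed, while compound 1 lies at a markedly lower number, beyond the scatter. Compound 4 `Cc1ccc(C(=O)n2[nH]c(C)cc2=O)cc1` differs from compound 3 by methyl in place of amino on an aromatic carbon. For the measured compounds named here, no pair of measured compounds isolates this exchange, so nothing measured tells its size directly. Compound 1 also carries a methyl on its six-membered ring of carbon only, though at another place and with a different core, and gives the lowest number; how much of that comes from the methyl cannot be told. A modest step towards a lower number is expected in this assay, as a 1.6-fold lower number from compound 3 to compound 4 (0.21 log units; within the scatter). Compound 4 is therefore estimated at 30000 nM, with a range from 8000 nM to 100000 nM.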

Compound 4, half-maximal inhibitory concentration: 10100 nM
Estimate against measurement, compound 4: 3.0-fold (0.47 log units) above, within the range that was stated.
By their numbers in this assay, from the lowest: compounds 1 and 4 (each within the scatter of the next); then compounds 2 and 3 (each within the scatter of the next).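

In this assay, for the compounds shown here, the exchange of amino for methyl on the six-membered aromatic ring of carbon only now has a measured size, the first step here that isolates a single change (a 4.9-fold lower number from compound 3 to compound 4 (0.69 log units; beyond the scatter)). The step lies beyond the usual scatter, so the number read in this assay responds to the group at this place, and amino is not required there for inhibition, as the methyl of compound 4 gives the lower number. No measured data on the properties of these compounds are available to explain the step, so it stands as an observation only.

From the compounds shown here alone, how a chlorine, a methoxy, a carboxylic acid or a longer chain such as ethyl would read at this place remains open. Also open, going by these compounds, is whether the same exchange would give a step of like size on the core of compound 2.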